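From 2-methoxyphenoxy to phenylsulfanyl on a shared core

The source may report more compounds than this note shows. Statements on the series, on what has been measured and on what is new or still open speak of the compounds shown alone.

In a functional assay (aorta) with Oryctolagus cuniculus as the target (on this read-out higher numbers stand for weaker binding and lower numbers for tighter binding), compound 1 `COc1cc(OCCCN2CCC(C(c3ccc(F)cc3)c3ccc(F)cc3)CC2)ccc1C(C)=O` gives 3.16 nM, compound 2 `Fc1ccc(OCCCN2CCC(C(c3ccc(F)cc3)c3ccc(F)cc3)CC2)cc1` gives 1.26 nM, and compound 3 `COc1ccccc1OCCCN1CCC(C(c2ccc(F)cc2)c2ccc(F)cc2)CC1` gives 2.51 nM. Compound 3 thus stands within the usual scatter of both others, as shown by a 1.3-fold lower number from compound 1 to compound 3 (0.10 log units; within the scatter) and a 2.0-fold higher number from compound 2 to compound 3 (0.30 log units; within the scatter).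

Compound 4 `Fc1ccc(C(c2ccc(F)cc2)C2CCN(CCCSc3ccccc3)CC2)cc1` keeps the shared core and differs from compound 3 in one place: phenylsulfanyl in place of 2-methoxyphenoxy on a saturated chain carbon, three bonds along the chain from an amine nitrogen in a ring. Among the compounds with values here, no measured compound carries phenylsulfanyl, so no measured step tests this change directly. The closest guides are the swaps of the group on the oxygen. Of these, only a 2.5-fold lower number from compound 1 to compound 2 (0.40 log units; beyond the scatter) goes beyond the scatter, and it is modest. Across compounds 1, 2 and 3, then, quite different groups at this end of the chain shift the number only a little.

On that basis, no step beyond the scatter is expected in this assay. The estimated change is a 1.2-fold higher number from compound 3 to compound 4 (0.08 log units; within the scatter). For compound 4 the expected value is 3 nM, with an estimated range of 1 nM to 10 nM.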

Compound 4, dissociation constant: 3.16 nM
Compound 4: middle estimate off by 1.1-fold (0.02 log units), on the low side, and the stated range covers the measured number.
By their numbers in this assay, from the lowest: compounds 2, 3, 1 and 4 (each within the scatter of the next, the first and the last beyond it).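

In this assay, moving from the oxygen-linked end of compound 3 to the sulfur-linked phenylsulfanyl end gives a 1.3-fold higher number from compound 3 to compound 4 (0.10 log units; within the scatter), so this change of linking atom, made together with the loss of the methoxy group, stays within the usual spread of the measurements. Compared with the other two ethers, the same end gives no change at the digits printed from compound 1 to compound 4 (within the scatter) and a 2.5-fold higher number from compound 2 to compound 4 (0.40 log units; beyond the scatter), which makes the 4-fluorophenoxy group the only one of the three whose replacement by phenylsulfanyl moves the number beyond the scatter, and then only modestly. Nothing measured here explains why the numbers fall this way.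

As far as these compounds go, whether the sulfur or the missing methoxy group contributes more remains open, and an unsubstituted phenoxy end or a 2-methoxyphenylsulfanyl end would separate the two. Also open, from the compounds shown here alone, is how an amine, a carboxylic acid or a longer chain at this end would read in this assay.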